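Side-chain exchange on the shared core: notes toward compound 3

The compounds below may be only part of what the source reports. "The series", "measured", "known", "first", "only" and "open" are said of these compounds alone.

Two compounds of the series have a number in a functional assay (B cells) with Mus musculus as the target; a higher number here means that more compound is needed for the effect, a lower number that less compound is needed. Compound 1 `Nc1nc(O)c2c(n1)n(C1OC(CO)[C@@H](O)[C@H]1O)c(=O)n2C/C=C/c1ccccc1` gives 103 uM in this assay. Compound 2 `CCCn1c(=O)n(C2CCC(COC(C)=O)O2)c2nc(NC(C)=O)nc(O)c21` gives 154 uM in this assay. These two values lie within the scatter of each other, so compound 1 and compound 2 are taken as equivalent on the numbers shown, and no order between them is read. For the measured compounds named here, no pair of measured compounds differs in a single place, so nothing is yet known about how any one structural change moves the read-out.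

Compound 3 `Nc1nc(O)c2c(n1)n(C1OC(CO)[C@@H](O)[C@H]1O)c(=O)n2CC(O)CSc1ccccc1` has not been measured. It differs from compound 1 in one place: 1-hydroxy-2-(phenylsulfanyl)ethyl in place of 2-phenylethenyl on a saturated chain carbon bound to an aromatic nitrogen. The entering group keeps a six-membered aromatic ring of carbon only but adds one hydrogen-bond donor and two hydrogen-bond acceptors, with a sulfur in the chain, where the leaving group had a double bond outside aromatic rings and no donor or acceptor. Going by the values given here, with no measured step to lean on, the step from compound 1 to compound 3 is expected to be a 1.2-fold higher number from compound 1 to compound 3 (0.07 log units; within the scatter), with no direction clear beyond the scatter. Compound 3 is therefore estimated at 120 uM in this assay, within a range from 40 uM to 400 uM.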

Compound 3, concentration for half-maximal effect: 142 uM
Compound 3: the middle estimate sits 1.2-fold (0.07 log units) below what was measured; the range from low to high includes it.
By their numbers in this assay, from the lowest: compounds 1, 3 and 2 (each within the scatter of the next).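

For the compounds shown here, this is the first single-place step: in this assay, replacing 2-phenylethenyl with 1-hydroxy-2-(phenylsulfanyl)ethyl on a saturated chain carbon bound to an aromatic nitrogen gives a 1.4-fold higher number from compound 1 to compound 3 (0.14 log units; within the scatter). At this position, the read-out therefore shows no difference between a group with a double bond and no hydrogen-bond donor or acceptor and a larger group with a hydroxy, a sulfur and hydrogen-bond donor and acceptor counts above zero, while both groups keep the six-membered aromatic ring of carbon only. No measured evidence is available to explain this outcome.

The hydroxy and the sulfur enter together in this one step, so the compounds shown leave open what each does alone and whether one could offset the other. Also open, on these data alone, is whether a primary amine or a carboxylic acid on this chain, or a group without the aromatic ring, such as a plain butyl chain, would move the number in this assay beyond the scatter.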